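The compounds below may be only part of what the source reports. "The series", "measured", "known", "first", "only" and "open" are said of these compounds alone.

In an in vitro assay on Sf21 cells for inhibition of high affinity 3',5'-cyclic-AMP phosphodiesterase 7A (Homo sapiens), read by scintillation proximity assay, with a stated time of 30 min (on this read-out lower numbers stand for stronger inhibition and higher numbers for weaker inhibition), compound 3 `CC(=O)c1ccc(NC(=O)c2cn(Cc3c(F)cccc3Cl)c3ccc(=O)[nH]c3c2=O)cc1` gives 18 nM, the lowest of the two numbers measured in the series; the nearest is compound 1 `CCN(CC)c1ccc(NC(=O)c2cn(Cc3c(F)cccc3F)c3ccc(=O)[nH]c3c2=O)cc1` at 46 nM. Compound 2 `O=C(Nc1c(F)cccc1F)c1cn(Cc2c(F)cccc2F)c2ccc(=O)[nH]c2c1=O` reaches only a limit, > 1000 nM (the limit of > 1000 nM in this assay, at which 1 of the 3 values shown sits). Compound 4 `NS(=O)(=O)c1ccc(NC(=O)c2cn(Cc3c(F)cccc3Cl)c3ccc(=O)[nH]c3c2=O)cc1` differs from compound 3 by sulfamoyl in place of acetyl on an aromatic carbon. Going by the values given here, the single measured step, an at least 21-fold higher number from compound 1 to compound 2 (1.33 log units; beyond the scatter), replaces the whole group on the amide nitrogen rather than one substituent on its phenyl ring, so it bears only loosely on the present change: it shows that this part of the molecule matters in this assay, but gives no size for exchanging one group on that ring for another. The step from compound 3 to compound 4 is therefore expected to be a 1.7-fold higher number from compound 3 to compound 4 (0.22 log units; within the scatter), within the scatter or slightly weaker. Compound 4 is estimated at 30 nM, with a range of 10 nM to 100 nM.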

Compound 4, half-maximal inhibitory concentration: 20 nM
The estimate for compound 4 lay 1.5-fold (0.18 log units) above the measured number; the range from low to high includes it.
By their numbers in this assay, from the lowest: compounds 3 and 4 (each within the scatter of the next); then compound 1. At a limit, above all of these: compound 2.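

In this assay, the exchange of 4-acetylphenyl for 4-sulfamoylphenyl gives a 1.1-fold higher number from compound 3 to compound 4 (0.05 log units; within the scatter), so acetyl and sulfamoyl cannot be told apart on this aromatic carbon, para to a large group. This provides a size for exchanging one group on that ring, which the earlier step, a replacement of the whole group on the amide nitrogen, could not give. Nothing on hand gives a reason for the match. Open, going by these compounds, is whether an amine or a carboxylic acid at this place would read alike. Methylsulfonyl in place of sulfamoyl also remains open.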